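Adding a Methyl to the Propylamino Chain of Compound 1

The compounds below may be only part of what the source reports. "The series", "measured", "known", "first", "only" and "open" are said of these compounds alone.

Compounds measured so far:
compound 1, `CCCNC(=C\C(=O)/C=C/c1ccc(O)c(OC)c1)/C=C/c1ccc(O)c(OC)c1`, 141%
compound 2, `CC(C)CNC(=C\C(=O)/C=C/c1ccc(O)cc1)/C=C/c1ccc(O)cc1`, 119%
compound 3, `CC(=O)Oc1ccc(/C=C/C(=O)/C=C(/C=C/c2ccc(OC(C)=O)cc2)NCC(C)C)cc1`, 53%

Of the compounds shown here, three have been tested in a functional assay on EA.hy 926 cells (Homo sapiens), read by fluorescence, tested at 10 uM; a higher number here means a stronger effect of the compound at the concentration tested, a lower number a weaker effect. Compound 1 stands at the top of this small set: in this assay compound 1 gives 141%, a value that lies beyond the scatter above both others. Compound 2 comes nearest with 119%, and compound 3 sits furthest away with 53%. Going by the values given here, compounds 2 and 3 both carry an isobutylamino group, yet they differ from compound 1 in more than one place, so no single structural step connects them to it.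

The next compound, compound 4, has the structure `COc1cc(/C=C/C(=O)/C=C(/C=C/c2ccc(O)c(OC)c2)NCC(C)C)ccc1O`. It is built from compound 1 by one change: methyl in place of hydrogen on a saturated chain carbon bound to two saturated chain carbons. Nothing in the measured set isolates this change on its own, so the size of the step is open. With compound 2 showing 119% while carrying the isobutylamino group, a small step downward from compound 1, near the edge of the scatter, is expected for compound 4, that is a number 11 percentage points lower from compound 1 to compound 4 (beyond the scatter). In this assay compound 4 is therefore estimated to give 130%, within a range from 100% to 160%.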

Compound 4, a percentage reported as activity, at one concentration (the size of the read-out at that concentration, not a potency): 100%
Compound 4: the middle estimate sits 30 percentage points above what was measured; the range from low to high includes it.
By their numbers in this assay, from the lowest: compound 3; then compound 4; then compound 2; then compound 1.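

Propylamino to isobutylamino is the first change in this set that can be read on its own, and in this assay it gives a number 41 percentage points lower from compound 1 to compound 4 (beyond the scatter) as a large step. The saturated chain carbon bound to two saturated chain carbons is therefore a place where the read-out responds strongly: a single methyl of one carbon, with no ring, no charge and no hydrogen-bond donors or acceptors, is enough to shift it while the rest of compound 1 stays the same. What lies behind this step cannot be said from the data at hand.

Going by these compounds, it remains open whether the branch itself matters or simply the added carbon, a question that a straight butylamino chain, carrying the same number of carbons without a branch, could help to settle. On these data alone, it is also open whether the same change would have a step of similar size on the core of compound 2, and whether an ethyl or a cyclopropyl group at the end of the amine would be tolerated any better.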